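The source may report more compounds than this note shows. Statements on the series, on what has been measured and on what is new or still open speak of the compounds shown alone.

Measured compounds:
compound 1, `CC#CCn1c(N2CCC[C@@H](N)C2)nc2c1c(=O)n(CCCN1CCN(c3ncc(OC)cn3)CC1)c(=O)n2C`, 2260 nM
compound 2, `CC#CCn1c(N2CCC[C@@H](N)C2)nc2c1c(=O)n(CCCN1CCN(c3ncc(F)cn3)CC1)c(=O)n2C`, 1410 nM

Both numbers come from a functional assay on HEK293 cells for agonist activity at Glucose-dependent insulinotropic receptor (Homo sapiens), read by a luciferase reporter; on this read-out lower numbers stand for an effect already at smaller amounts and higher numbers for an effect only at larger amounts of compound. In this assay compound 1 gives 2260 nM and compound 2 gives 1410 nM. Among the measured compounds shown here, the single measured step is a 1.6-fold lower number from compound 1 to compound 2 (0.20 log units; within the scatter), a change of fluoro in place of methoxy on an aromatic carbon. Compound 2 carries the lowest of the two numbers, its nearest neighbour being compound 1, and since the two lie within the scatter of each other no order between them is claimed.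

Compound 3, `CC#CCn1c(N2CCC[C@@H](N)C2)nc2c1c(=O)n(CCCN1CCN(c3ncc(CC)cn3)CC1)c(=O)n2C`, has yet to be measured in this assay. It differs from compound 2 by ethyl in place of fluoro on an aromatic carbon. For the measured compounds named here, the only measured step at this aromatic carbon, a 1.6-fold lower number from compound 1 to compound 2 (0.20 log units; within the scatter), concerned methoxy to fluoro and stayed within the scatter; no step from fluoro to an alkyl group has been measured. On that basis a step of a 1.0-fold lower number from compound 2 to compound 3 (0.00 log units; within the scatter) is expected, not beyond the scatter in either direction. Compound 3 is therefore estimated at 1400 nM with a range from 500 nM to 4000 nM.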

Compound 3, half-maximal effective concentration: 3990 nM
Beside the measured number, compound 3's estimate is 2.9-fold (0.45 log units) below it, and the stated range covers the measured number.
By their numbers in this assay, from the lowest: compounds 2, 1 and 3 (each within the scatter of the next, the first and the last beyond it).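

Among the compounds shown here, on the six-membered aromatic ring, at the carbon two atoms from the ring nitrogen and para to a large group, this assay now gives the first step beyond the scatter: a 2.8-fold higher number from compound 2 to compound 3 (0.45 log units; beyond the scatter) for ethyl in place of fluoro. The substituent at this carbon can therefore move the number, which the methoxy to fluoro step alone did not show, although the move remains modest. With ethyl in place of methoxy the result is a 1.8-fold higher number from compound 1 to compound 3 (0.25 log units; within the scatter) and stays within the scatter, so only fluoro and ethyl are separated, while methoxy cannot be placed apart from either; nothing available accounts for the gap between fluoro and ethyl.

Going by these compounds, whether an amine, a carboxylic acid or a longer chain such as propyl at this same carbon would sit with fluoro, with ethyl or outside both remains open. On these data alone, all three compounds share everything else, so it is also open whether the step from fluoro to ethyl would keep its size with a different group on the shared core.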